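The source may report more compounds than this note shows. Statements on the series, on what has been measured and on what is new or still open speak of the compounds shown alone.

Compound 1 `Cc1ccc(OCCn2ccc(=O)n(Cc3ccccc3)c2=O)cc1` gives 187000 nM in an ADME assay on MT4 cells (Homo sapiens) for cytotoxicity, read by MTT assay, with a stated time of 4 days; a lower number here means that less compound is tolerated, a higher number that more compound is tolerated. Compound 2 `Cc1ccc(OCCn2ccc(=O)n(Cc3cc(C)cc(C)c3)c2=O)cc1` carries 3,5-dimethylphenyl in place of phenyl on a saturated chain carbon bound to an aromatic nitrogen on the same core. In this assay compound 2 reaches only a limit, > 343000 nM. The step of an at least 1.8-fold higher number from compound 1 to compound 2 (0.26 log units; that floor lies within the scatter) is therefore known only as a floor, because compound 2 sits at the limit of > 343000 nM in this assay, at which 1 of the 3 values shown sits.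

Compound 3 `O=c1ccn(C/C=C/c2ccccc2)c(=O)n1Cc1ccccc1` is built on another core; the difference between the two cores is not broken down here. In this assay compound 3 gives 160000 nM, a number that lies within the usual scatter of the value of compound 1.

Compound 4 `Cc1cc(C)cc(Cn2c(=O)ccn(C/C=C/c3ccccc3)c2=O)c1` has not yet been measured. It differs from compound 3 by 3,5-dimethylphenyl in place of phenyl on a saturated chain carbon bound to an aromatic nitrogen, the same change, at the same place, that leads from compound 1 to compound 2. The step of a 1.9-fold higher number from compound 3 to compound 4 (0.27 log units; within the scatter) is expected to be of a size comparable to the floor set by an at least 1.8-fold higher number from compound 1 to compound 2 (0.26 log units; that floor lies within the scatter). Since compound 2 sits at the limit of > 343000 nM in this assay, at which 1 of the 3 values shown sits, compound 4 may likewise end at a limit. Compound 4 is estimated to give 300000 nM in this assay, expected between 150000 nM and 600000 nM.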

Compound 4, half-maximal cytotoxic concentration: 257000 nM
Compound 4: the middle estimate sits 1.2-fold (0.07 log units) above what was measured; low and high end bracket the measured number.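

In this assay, placing 3,5-dimethylphenyl in place of phenyl on the core of compound 3 gives a 1.6-fold higher number from compound 3 to compound 4 (0.21 log units; within the scatter). Set beside the earlier step on the other core, this result is compatible with the change carrying over, but neither step shows an effect beyond the scatter, and the size on the first core is known only as a floor: the same change on two cores in this assay, an at least 1.8-fold higher number (0.26 log units; that floor lies within the scatter) from compound 1 to compound 2 and a 1.6-fold higher number (0.21 log units; within the scatter) from compound 3 to compound 4; the limit leaves it open whether they differ The remaining comparison, an at least 1.3-fold lower number from compound 2 to compound 4 (0.12 log units; that floor lies within the scatter), with 2-phenylethenyl in place of (4-methylphenoxy)methyl, also gives only a floor within the scatter, so it does not separate these two chains.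

The compounds shown leave open whether other groups on the phenyl ring, such as methoxy or trifluoromethyl, would move the number in this assay beyond the scatter. They also leave open what a chain ending in an amine or a carboxylic acid, in place of 2-phenylethenyl or (4-methylphenoxy)methyl, would give on this core.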